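Shortening the Chain of Compound 2

The source may report more compounds than this note shows. Statements on the series, on what has been measured and on what is new or still open speak of the compounds shown alone.

In a functional assay on SH-SY5Y cells (Homo sapiens) for cytotoxicity, read by MTT assay, with a stated time of 56 h (a higher number here means that more compound is needed for the effect, a lower number that less compound is needed), compound 1 (`O=C(CCCCCCCc1cnc(-c2cccnc2)s1)Nc1ccccc1-c1ccccc1`) gives 5250 nM and compound 2 (`c1ccc(-c2ccccc2-c2cn(CCCCCCCCn3cc(-c4cccnc4)nn3)nn2)cc1`) gives 74.5 nM as the lower of the two numbers, a gap well beyond the scatter. Compound 3 (`c1ccc(-c2ccccc2-c2cn(CCCCCCCn3cc(-c4cccnc4)nn3)nn2)cc1`) differs from compound 2 by 4-(pyridin-3-yl)-1H-1,2,3-triazol-1-yl in place of (4-(pyridin-3-yl)-1H-1,2,3-triazol-1-yl)methyl on a saturated chain carbon, seven bonds along the chain from an aromatic nitrogen with 4-(pyridin-3-yl)-1H-1,2,3-triazol-1-yl in place of (4-(pyridin-3-yl)-1H-1,2,3-triazol-1-yl)methyl on a saturated chain carbon, seven bonds along the chain from an aromatic nitrogen. For the measured compounds named here, no measured pair shows this kind of change, so only a modest upward step in this assay is expected, an estimated 1.9-fold higher number from compound 2 to compound 3 (0.27 log units; within the scatter) that may stay close to the scatter. Compound 3 is expected to give 140 nM with an estimated range of 40 nM to 500 nM in this measurement.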

Compound 3, half-maximal effective concentration: 9.1 nM
Compound 3: middle estimate off by 15-fold (1.19 log units), on the high side; measured number below the stated range.
By their numbers in this assay, from the lowest: compound 3; then compound 2; then compound 1.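

In this assay, the saturated chain proves a sensitive place: 4-(pyridin-3-yl)-1H-1,2,3-triazol-1-yl in place of (4-(pyridin-3-yl)-1H-1,2,3-triazol-1-yl)methyl gives an 8.2-fold lower number from compound 2 to compound 3 (0.91 log units; beyond the scatter), so less compound is needed for the effect. The group that enters has the same rings as the group that leaves. No measurement shown explains the size of this step. A single step cannot establish a trend with chain length. From the compounds shown here alone, whether a still shorter chain, a longer chain or an amine within the chain would lower the number further remains open.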